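Turning One Stereocentre in Compound 1

This account rests on a few compounds, and the source may have more. Where it says the series, first, only, none or still open, it means among the compounds named here.

compound 1 `CN1CC[C@H]2CCC[C@@H](NS(=O)(=O)c3ccccc3)[C@H]2C1` gives 9.17
compound 2 `CN1CC[C@H]2CCC[C@@H](OC(=O)c3ccc(Cl)cc3)[C@@H]2C1` gives 8.75
compound 3 `CN1CC[C@H]2CCC[C@@H](OC(=O)c3ccc(Cl)cc3)[C@H]2C1` gives 8.9

In a physicochemical assay for acid dissociation, compound 1 stands level with compound 3 within the scatter, and clearly higher than compound 2. Compound 4 `CN1CC[C@H]2CCC[C@@H](NS(=O)(=O)c3ccccc3)[C@@H]2C1` is still unmeasured. The change from compound 1 to compound 4 is this: the two compounds have the same atoms and bonds and differ only in configuration as drawn: 1 of 3 stereo elements differ; a stereocentre at a saturated ring carbon is drawn R in compound 1 and S in compound 4. Among the compounds with values here, one measured step bears on it. Given (the fact that compounds 2 and 3 differ only in the configuration as drawn), the value comes out a number 0.15 log units higher from compound 2 to compound 3 (within the scatter). There, a stereocentre at a saturated ring carbon is drawn S in compound 2 and R in compound 3, so the new step runs the opposite way, from R to S. In this assay the expected step, no larger than the scatter, is a number 0.15 log units lower from compound 1 to compound 4 (within the scatter). For compound 4 the estimated value is 9.02, with an expected range from 8.72 to 9.32.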

Compound 4, acid dissociation constant: 8.87
Compound 4: middle estimate off by 0.15 log units, on the high side; the measured number falls inside the stated range.
By their numbers in this assay, from the lowest: compounds 2, 4, 3 and 1 (each within the scatter of the next, the first and the last beyond it).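

In this assay, turning a stereocentre at a saturated ring carbon from R to S gives a number 0.30 log units lower from compound 1 to compound 4 (within the scatter), so this change stays within the scatter with the benzenesulfonamide as well. The earlier compounds shown here showed this change only with the 4-chlorobenzoate ester, so a step this small now holds for two different groups on the shared core. Whatever separates this pair can lie only at that one stereocentre: the fact that compounds 1 and 4 differ only in the configuration as drawn. From the compounds shown here alone, whether the step stays this small with another group there, such as a simple amine or a carboxylic acid, remains open.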